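The source may hold more compounds than are shown below. What is called first, only, known or untested is meant among the compounds shown, and "the series" means these compounds.

Compound 1 `O=C1N=C(N2N=C(c3ccccc3)CC2c2ccccc2O)S/C1=C1/C(=O)Nc2ccccc21` and compound 2 `O=C1N=C(N2N=C(c3ccccc3)CC2c2ccc(Cl)cc2)S/C1=C1/C(=O)Nc2ccccc21` share one core. In a functional assay on cells (Cancer cell lines, Homo sapiens) for cytotoxicity, read by sulforhodamine B assay, with a stated time of 48 h (a higher number here means a weaker inhibitor of growth, a lower number a stronger inhibitor of growth), compound 1 gives 2090 nM, and compound 2 gives 320 nM, with a 6.5-fold lower number from compound 1 to compound 2 (0.81 log units; beyond the scatter). Compound 2 thus holds the lowest of the two numbers. Compound 3 `Cc1ccc2c(c1)/C(=C1\SC(N3N=C(c4ccccc4)CC3c3ccc(Cl)cc3)=NC1=O)C(=O)N2` differs from compound 2 by methyl in place of hydrogen on an aromatic carbon. Going by the values given here, no measured step touches this ring, so nothing among the measured compounds bears on it directly; the one measured step concerns a different ring. Compound 3 is therefore expected to stay within the scatter of compound 2, with no change at the digits printed from compound 2 to compound 3 (within the scatter). In this assay the value of compound 3 is estimated at 320 nM, from 120 nM to 850 nM.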

Compound 3, concentration for 50% growth inhibition: 800 nM
The estimate for compound 3 lay 2.5-fold (0.40 log units) below the measured number; the range from low to high includes it.
By their numbers in this assay, from the lowest: compound 2; then compound 3; then compound 1.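

Going by these compounds alone, at this position, on an aromatic carbon of the six-membered aromatic ring of carbon only, the earlier compounds offered no measured step, and the ring now proves not to be silent in this assay. Methyl in place of hydrogen gives a 2.5-fold higher number from compound 2 to compound 3 (0.40 log units; beyond the scatter), so even this single added carbon moves the number upward. Nothing at hand gives a cause for this step. As far as these compounds go, whether a methoxy group, a fluorine atom or an amine at this carbon would move the number the same way remains open, as does the effect of methyl on the other carbons of this ring.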